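Nitro to methoxy on the benzyl ether of compound 2

A few compounds are considered here, and "the series" means these few. Any claim that something is new, unique, unknown or untested is made for them only; others in the source may bear on it.

Among the measured compounds shown here, compound 2 `COc1cccc(OC)c1OCCNCCOc1ccccc1OCc1cccc([N+](=O)[O-])c1` stands lowest of the two numbers so far in an assay on CHO cells for displacement of a labelled ligand from Alpha-1D adrenergic receptor (Homo sapiens) (on this read-out higher numbers stand for weaker inhibition and lower numbers for stronger inhibition), where compound 2 gives 0.0631 nM. Its nearest neighbour is compound 1 `COc1cccc(OC)c1OCCNCCOc1ccccc1OCc1ccccc1[N+](=O)[O-]`, which in this assay gives 0.912 nM; the move from compound 1 to compound 2 was a 14-fold lower number from compound 1 to compound 2 (1.16 log units; beyond the scatter). Compound 3 `COc1ccc(COc2ccccc2OCCNCCOc2c(OC)cccc2OC)cc1` is not yet measured. The change is 4-methoxyphenyl in place of 3-nitrophenyl on a saturated chain carbon bound to an oxygen on an aromatic ring. For the measured compounds named here, no measured step exchanges a nitro group for a methoxy group; the only step in hand moves the nitro group around the ring and shows that this assay answers strongly to what sits on this ring. The step from compound 2 to compound 3 is therefore expected to go upward, most likely a 6.3-fold higher number from compound 2 to compound 3 (0.80 log units; beyond the scatter), with wide uncertainty. Compound 3 is estimated at 0.4 nM, within a range from 0.08 nM to 2 nM.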

Compound 3, inhibition constant: 0.1 nM
For compound 3 the middle estimate is 4.0-fold (0.60 log units) above the measured one; measured number inside the range.
By their numbers in this assay, from the lowest: compounds 2 and 3 (each within the scatter of the next); then compound 1.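

In this assay, 4-methoxyphenyl and 3-nitrophenyl cannot be told apart on the saturated chain carbon bound to an oxygen on an aromatic ring (a 1.6-fold higher number from compound 2 to compound 3 (0.20 log units; within the scatter)), so a nitro group is not needed here for a number this low. The 2-nitrophenyl of compound 1 stays apart from 4-methoxyphenyl as well (a 9.1-fold lower number from compound 1 to compound 3 (0.96 log units; beyond the scatter)), which leaves compound 1 alone at the higher end among these three compounds. Nothing at hand bears on why these groups read as they do.

Nitro and methoxy are shown at no common place on this ring, so the exchange of group and the shift of its place remain unseparated. As far as these compounds go, how an unsubstituted phenyl, or a ring carrying a carboxylic acid or a dimethylamino group, would read at this position also stays open.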